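A Larger Aromatic Ring on the Ether Oxygen

This account rests on a few compounds, and the source may have more. Where it says the series, first, only, none or still open, it means among the compounds named here.

Compound 1 `O=C(CSc1nc2ccccc2s1)N/N=C/c1ccc(Oc2ccccc2)cc1` was measured in a physicochemical assay for lipophilicity, in phosphate buffer, measured as octanol-water partition, with a stated time of 24 h (on this read-out lower numbers stand for lower lipophilicity and higher numbers for higher lipophilicity), and gives 5.6. Compound 2 `C(=N/Nc1nc2ccccc2s1)\c1ccc(Oc2ccc3ccccc3c2)cc1` carries the same naphthalen-2-yl ether that is of interest here, but differs from compound 1 in more than one place; in this assay compound 2 gives 5.6, level with compound 1 at the digits shown, a gap within the usual scatter. Compound 3 `O=C(CSc1nc2ccccc2s1)N/N=C/c1ccc(Oc2ccc3ccccc3c2)cc1` has not yet been measured. It differs from compound 1 in one place only: naphthalen-2-yl in place of phenyl on an oxygen on an aromatic ring. Among the measured compounds shown here, no two measured compounds differ in this single place, so the size of this step cannot be read off from what has been measured. For compound 3 the expectation is a rise in this assay of about a number 0.70 log units higher from compound 1 to compound 3 (beyond the scatter), a step beyond the scatter. Compound 3 is therefore expected to give 6.3, within a range from 5.7 to 6.9.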

Compound 3, partition coefficient: 5.9
Beside the measured number, compound 3's estimate is 0.40 log units above it, and the stated range covers the measured number.
By their numbers in this assay, from the lowest: compounds 1, 2 and 3 (each within the scatter of the next).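

With this pair the change can be read on its own, because compound 1 and compound 3 differ in one place only. In this assay, naphthalen-2-yl in place of phenyl on an oxygen on an aromatic ring gives a number 0.30 log units higher from compound 1 to compound 3 (within the scatter). So a group with two six-membered aromatic rings of carbon in place of one does not, in this single pair, separate the two compounds on this read-out. Nothing available here speaks to the reason for this result.

Going by these compounds, this is one pair on one core, so it remains open whether the same change would stay within the scatter on another core. On these data alone, it also remains open whether an amine, a carboxylic acid or a longer alkyl chain in place of phenyl on this oxygen would move the number clear of the scatter.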